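The source may hold more compounds than are shown below. What is called first, only, known or untested is meant among the compounds shown, and "the series" means these compounds.

Three compounds have numbers in an assay on IM-9 cells for binding affinity to Substance-P receptor (Homo sapiens); on this read-out lower numbers stand for stronger inhibition and higher numbers for weaker inhibition. Compound 1 `Cc1ccccc1-c1c(C(=O)N(C)Cc2ccccc2Cl)n(C)c(=O)c2ccccc12` gives 19 nM. Compound 3 `COc1ccccc1CN(C)C(=O)c1c(-c2ccccc2C)c2ccccc2c(=O)n1C` gives 16 nM. Compound 2 `COc1ccccc1CN(C)C(=O)c1c(-c2ccc(F)cc2)c2cccnc2c(=O)n1C` gives 2.5 nM, the lowest of the three; the difference between the core of compound 2 and the core of compound 3 is not broken down here.

Within the measured set one single change occurs, (chloro in place of methoxy on an aromatic carbon), and it moves the number by a 1.2-fold higher number from compound 3 to compound 1 (0.07 log units; within the scatter).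

Compound 4 `CN(Cc1ccccc1Cl)C(=O)c1c(-c2ccc(F)cc2)c2cccnc2c(=O)n1C` carries the same change relative to compound 2, namely (chloro in place of methoxy on an aromatic carbon). Among the compounds with values here, only one measured precedent exists for this change, so the expected step is of like size: a 1.2-fold higher number from compound 2 to compound 4 (0.08 log units; within the scatter), resting on the one precedent, a 1.2-fold higher number from compound 3 to compound 1 (0.07 log units; within the scatter). Compound 4 is therefore estimated at 3 nM, with a likely range from 1.3 nM to 7 nM.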

Compound 4, half-maximal inhibitory concentration: 32 nM
Compound 4: middle estimate off by 11-fold (1.03 log units), on the low side, outside the stated range (above it).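

Chloro in place of methoxy does not carry over unchanged between cores in this assay: on the core of compound 2 it gives a 13-fold higher number from compound 2 to compound 4 (1.11 log units; beyond the scatter). The size of this step therefore depends on the core: the same change on two cores in this assay, a 1.2-fold higher number (0.07 log units; within the scatter) from compound 3 to compound 1 and a 13-fold higher number (1.11 log units; beyond the scatter) from compound 2 to compound 4, 11-fold (1.03 log units) apart, beyond the scatter of two such steps. These two pairs do not show which part of the core sets the difference, as the core of compound 2 and the core of compound 3 differ in more than one place.

Still open, on these data alone, is whether ethoxy, hydroxy or bromo on that aromatic carbon would read closer to compound 2 or to compound 4. Also open, as far as these compounds go, is how the same change would behave on a core that differs from the core of compound 2 in one place only.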